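Pyridyl-to-fluorophenyl exchange on the biaryl arm of compound 1

A few compounds are considered here, and "the series" means these few. Any claim that something is new, unique, unknown or untested is made for them only; others in the source may bear on it.

Three compounds of this series have a number in a physicochemical assay for lipophilicity, read by HPLC, at pH 7.5; a higher number here means a more lipophilic compound, a lower number a more polar compound. Compound 1 `CC[C@@H](Nc1c(C#N)c(-c2ccc(-c3ncccc3C)cc2)nc2cnccc12)C(N)=O` gives 2. Compound 2 `CCOc1ccccc1-c1ccc(-c2nc3cnccc3c(C[C@H](C)C(=O)O)c2C#N)cc1` gives 2.2, and compound 3 `CC[C@H](Nc1c(C#N)c(-c2ccc(Br)cc2)nc2cnccc12)C(N)=O` gives 2.3. The gap from compound 1 to compound 2 and to compound 3 lies within the scatter in each case, so the three cannot be ordered on these numbers.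

Compound 4 `CC[C@@H](Nc1c(C#N)c(-c2ccc(-c3cccc(C)c3F)cc2)nc2cnccc12)C(N)=O` is not yet measured. It differs from compound 1 in one place: 2-fluoro-3-methylphenyl in place of 3-methylpyridin-2-yl on an aromatic carbon. Within the data shown here, no measured pair follows this change, so its size is unknown; a step beyond the scatter toward the higher side is expected, and for compound 4 the estimate is 3, between 2.4 and 3.6, which is expected to mean a step of a number 1.00 log units higher from compound 1 to compound 4 (beyond the scatter).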

Compound 4, distribution coefficient: 3
Beside the measured number, compound 4's estimate shows no gap at the digits printed, and the stated range covers the measured number.
By their numbers in this assay, from the lowest: compounds 1, 2 and 3 (each within the scatter of the next); then compound 4.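

Among these compounds, at this position, para to a large group, the compounds now give a first step that can be read in this assay: a step of a number 1.00 log units higher from compound 1 to compound 4 (beyond the scatter). The exchange removes the ring nitrogen and adds fluorine in a single move, so the step cannot be divided between the two. Nothing measured here gives a cause for the step.

The compounds shown leave open where a 3-methylphenyl group without fluorine would stand in this assay. Also open, as far as these compounds go, is what an amine or a carboxylic acid on the entering ring would give at this position.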